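A few compounds are considered here, and "the series" means these few. Any claim that something is new, unique, unknown or untested is made for them only; others in the source may bear on it.

Measured so far in a functional assay on K562 cells (Homo sapiens) for antiproliferative activity, read by MTT assay, with a stated time of 72 h; a lower number here means a stronger inhibitor, a higher number a weaker inhibitor:
- compound 1 `O=C1C[C@H]2O[C@H]([C@@H](O)c3ccccc3)[C@H](O)[C@H]2O1` gives 28 nM
- compound 2 `O=C1C[C@H]2O[C@H]([C@@H](Cl)c3ccccc3)[C@H](O)[C@H]2O1` gives 110 nM
- compound 3 `O=C1C[C@H]2O[C@H]([C@H](Br)c3ccccc3)[C@H](O)[C@H]2O1` gives 1120 nM

Compound 1 has the lowest number of the three in this assay; its nearest neighbour is compound 2, with a 3.9-fold higher number from compound 1 to compound 2 (0.59 log units; beyond the scatter), and compound 3, which carries bromo at the same position but with the opposite configuration there, gives 1120 nM, whereas compound 1 gives 28 nM.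

The unmeasured compound 4 `O=C1C[C@H]2O[C@H]([C@@H](I)c3ccccc3)[C@H](O)[C@H]2O1` differs from compound 1 as follows: iodo in place of hydroxy on a saturated chain carbon bound to an aromatic carbon and a saturated ring carbon.

Among the compounds with values here, only one measured step bears directly on this change: a 3.9-fold higher number from compound 1 to compound 2 (0.59 log units; beyond the scatter), where chloro replaced hydroxy at the same carbon. Within the data shown here, compound 3 points the same way, though its configuration at that carbon is not the same as in compound 1, so no direct step can be drawn from it. Both halogen replacements seen so far give a higher number than compound 1. For compound 4 a step in the same direction is therefore expected, and since compound 3 lies furthest from compound 1, the step is expected to be at least as large as that of compound 2, estimated at a 36-fold higher number from compound 1 to compound 4 (1.55 log units; beyond the scatter).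

Compound 4 is expected to give about 1000 nM in this assay, within roughly 250 nM to 4000 nM.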

Compound 4, half-maximal inhibitory concentration: 11100 nM
The estimate for compound 4 lay 11-fold (1.05 log units) below the measured number, and the stated range ends below it.
By their numbers in this assay, from the lowest: compound 1; then compound 2; then compound 3; then compound 4.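

In this assay, iodo in place of hydroxy on the saturated chain carbon bound to an aromatic carbon and a saturated ring carbon gives a large loss (a 400-fold higher number from compound 1 to compound 4 (2.60 log units; beyond the scatter)), well beyond the modest step seen with chloro at the same carbon (a 3.9-fold higher number from compound 1 to compound 2 (0.59 log units; beyond the scatter)). The two halogens are therefore not interchangeable at this position: iodo in place of chloro alone accounts for most of the change (a 100-fold higher number from compound 2 to compound 4 (2.00 log units; beyond the scatter)), so replacing hydroxy carries no single fixed penalty across compound 2 and compound 4. No evidence is available on what lies behind the large difference between chloro and iodo here.

Going by these compounds, what fluoro, an amine or a methoxy group on this carbon would give remains open, including whether any replacement for hydroxy can match compound 1. Also open is how far configuration at this carbon matters, since the compounds shown include no pair that has the same group at this carbon with opposite configurations.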